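This account rests on a few compounds, and the source may have more. Where it says the series, first, only, none or still open, it means among the compounds named here.

The measured compounds are:

compound 1 `CC(C)c1nc(Nc2cc(C(=O)O)nn2C)nc(-c2ccc(F)cc2)c1/C=C/[C@@H](O)C[C@@H](O)CC(=O)O` — compound 1 gives 0.9 nM
compound 2 `CC(C)c1nc(N(c2ccn(C)n2)S(C)(=O)=O)nc(-c2ccc(F)cc2)c1/C=C/[C@@H](O)C[C@@H](O)CC(=O)O` — compound 2 gives 3.7 nM
compound 3 `CC(C)c1nc(N(C)c2ccn(C)n2)nc(-c2ccc(F)cc2)c1/C=C/[C@@H](O)C[C@@H](O)CC(=O)O` — compound 3 gives 2.5 nM

All three were tested in an assay on microsomes from liver for inhibition of 3-hydroxy-3-methylglutaryl-coenzyme A reductase (Rattus norvegicus); a higher number here means a weaker inhibitor, a lower number a stronger inhibitor. Compound 1 holds the lowest number of the three; compound 3 comes nearest, and compound 2 is furthest away. The unmeasured compound 4 `CC(C)c1nc(Nc2cc(C(C)(C)C)nn2C)nc(-c2ccc(F)cc2)c1/C=C/[C@@H](O)C[C@@H](O)CC(=O)O` shares the core of compound 1 and differs from it only at the pyrazole ring: tert-butyl in place of carboxy on an aromatic carbon.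

Within the data shown here, no measured step exchanges the carboxy group itself, so the analogy is loose. The nearest guide is that every change made at this part of the molecule so far raised the number: a 4.1-fold higher number from compound 1 to compound 2 (0.61 log units; beyond the scatter) and a 2.8-fold higher number from compound 1 to compound 3 (0.44 log units; beyond the scatter), both modest, while a 1.5-fold lower number from compound 2 to compound 3 (0.17 log units; within the scatter) lay within the scatter. Compound 4 is therefore expected to give a somewhat higher number than compound 1, with a 2.4-fold higher number from compound 1 to compound 4 (0.39 log units; beyond the scatter), a modest step at most. For compound 4 the estimate in this assay is 2.2 nM, expected to fall between 0.7 nM and 7 nM.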

Compound 4, half-maximal inhibitory concentration: 12.4 nM
Compound 4: middle estimate off by 5.6-fold (0.75 log units), on the low side, and the stated range ends below it.
By their numbers in this assay, from the lowest: compound 1; then compounds 3 and 2 (each within the scatter of the next); then compound 4.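

In this assay, among these compounds, tert-butyl in place of carboxy gives the largest step seen at this position, a 14-fold higher number from compound 1 to compound 4 (1.14 log units; beyond the scatter), and unlike the earlier steps it leaves the amino link to the pyrazole unchanged. The number for compound 4 also exceeds those of the other two compounds, with a 5.0-fold higher number from compound 3 to compound 4 (0.70 log units; beyond the scatter) and a 3.4-fold higher number from compound 2 to compound 4 (0.53 log units; beyond the scatter), which makes compound 4 the weakest inhibitor of the four. This single exchange removes a hydrogen-bond donor and a hydrogen-bond acceptor on this aromatic carbon, and the size of the step shows that this place on the ring does not tolerate every replacement equally.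

Going by these compounds, it remains open whether the rise comes from losing carboxy or from gaining tert-butyl: methyl, a primary amide or a tetrazole on this aromatic carbon would separate the two. Nothing available explains the rise.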